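A few compounds are considered here, and "the series" means these few. Any claim that something is new, unique, unknown or untested is made for them only; others in the source may bear on it.

Working notes on the series, read in a functional assay on HeLa cells (Homo sapiens) for cytotoxicity, read by MTT assay, with a stated time of 48 h; on this read-out higher numbers stand for weaker inhibition and lower numbers for stronger inhibition. Compound 1 `COc1cc(/C=C/C(=O)C2=C(/C=C/c3ccc(O)c(OC)c3)NC(=O)NC2c2ccccc2O)ccc1O` gives 50000 nM, compound 2 `COc1cc(/C=C/C(=O)C2=C(/C=C/c3ccc(O)c(OC)c3)NC(=O)NC2c2c(Cl)cccc2Cl)ccc1O` gives 25000 nM, and compound 3 `COc1cc(/C=C/C(=O)C2=C(/C=C/c3ccc(O)c(OC)c3)NC(=S)NC2c2ccccc2)ccc1O` gives 25000 nM. Compound 3 stands level with compound 2 and within the scatter of compound 1, so the three values do not separate.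

Compound 4 `COc1cc(/C=C/C(=O)C2=C(/C=C/c3ccc(O)c(OC)c3)NC(=S)NC2c2ccc(C)cc2)ccc1O` differs from compound 3 by one change: methyl in place of hydrogen on an aromatic carbon, para to a large group (methyl in place of hydrogen on an aromatic carbon). Within the data shown here, no measured step makes this same change. Among the measured compounds shown here, the only step available, with 2,6-dichlorophenyl in place of 2-hydroxyphenyl, is a 2.0-fold lower number from compound 1 to compound 2 (0.30 log units; within the scatter), and it stays within the scatter. It is indirect evidence, but it gives no reason to expect a step beyond the scatter in this assay, and no direction can be assigned. The expected step is no change at the digits printed from compound 3 to compound 4 (within the scatter). Compound 4 is estimated at 25000 nM, with an expected range from 10000 nM to 50000 nM.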

Compound 4, half-maximal inhibitory concentration: 25000 nM
Estimate against measurement, compound 4: no gap at the digits printed; the measured number falls inside the stated range.
By their numbers in this assay, from the lowest: compounds 2, 3, 4 and 1 (each within the scatter of the next).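

In this assay, among these compounds, methyl in place of hydrogen on an aromatic carbon, para to a large group, reads as no change at the digits printed from compound 3 to compound 4 (within the scatter), the first direct reading of this change. The earlier step concerned other groups on a saturated ring carbon, whereas this pair isolates phenyl to 4-methylphenyl and shows that one added carbon at this position does not separate compound 4 from compound 3. No measurement bears on why this reading comes out as it does.

On these data alone, whether an amine, a carboxylic acid or a longer chain such as butyl at this position would give a step beyond the scatter stays open. The compounds shown also leave open whether any place on the shared core can move the number beyond the scatter.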